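The source may report more compounds than this note shows. Statements on the series, on what has been measured and on what is new or still open speak of the compounds shown alone.

Compound 2 `COc1cc(OC)c(C(=O)/C=C/c2ccc(F)cc2)c(OC)c1` gives 39% in a functional assay on Caco-2 cells (Homo sapiens), read by fluorescence and BrdU incorporation, with a stated time of 48 h, tested at 10 uM (on this read-out higher numbers stand for a weaker effect at the one concentration tested and lower numbers for a stronger effect), a number within the scatter of compound 1 `COc1cc(OC)c(C(=O)/C=C/c2ccccc2SC)c(OC)c1`, which in this assay gives 36%. Compound 3 `COc1cc(OC)c(C(=O)/C=C/c2ccc(Br)cc2)c(OC)c1` differs from compound 2 by bromo in place of fluoro on an aromatic carbon. Going by the values given here, the only step measured so far, a number 3 percentage points higher from compound 1 to compound 2 (within the scatter), concerns 4-fluorophenyl in place of 2-(methylsulfanyl)phenyl and lay within the scatter, so no measured step bears directly on bromo in place of fluoro. In this assay the step is expected to stay within the scatter, a number 1 percentage points lower from compound 2 to compound 3 (within the scatter). Compound 3 is therefore estimated at 38%, between 20% and 60%.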

Compound 3, a percentage reported as activity, at one concentration (the size of the read-out at that concentration, not a potency): 36%
Estimate against measurement, compound 3: 2 percentage points above; the range from low to high includes it.
By their numbers in this assay, from the lowest: compounds 1, 3 and 2 (each within the scatter of the next).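

In this assay, going by these compounds alone, bromo in place of fluoro on an aromatic carbon, para to a large group, gives a first halogen comparison at this position (a number 3 percentage points lower from compound 2 to compound 3 (within the scatter)), and the exchange lies within the scatter. The second step (no change at the digits printed from compound 1 to compound 3 (within the scatter)) shows that 4-bromophenyl and 2-(methylsulfanyl)phenyl also cannot be told apart on this read-out. No measured evidence bears on this result. From the compounds shown here alone, whether an amine or a carboxylic acid in place of the bromo would move the number beyond the scatter remains open.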